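The source may hold more compounds than are shown below. What is called first, only, known or untested is meant among the compounds shown, and "the series" means these compounds.

Measured so far:
compound 1, `CC1=CC[C@@H]([C@@](C)(O)CCCC(C)(C)NC=S)CC1`, 11000 nM;
compound 2, `CC1=CC[C@@H]([C@@](C)(O)CCCC(C)(C)NC(=S)N/N=C\c2ccc(C)cc2)CC1`, 6750 nM.

In a functional assay on PCO3 cells (Homo sapiens) for cytotoxicity, read by sulforhodamine B assay (on this read-out lower numbers stand for stronger inhibition of growth and higher numbers for weaker inhibition of growth), compound 2 gives the lowest of the two numbers, and the nearest is compound 1, whose number is higher by an amount that lies within the scatter. The next compound, compound 3, `CC1=CC[C@@H]([C@@](C)(O)CCCC(C)(C)NC(=S)N/N=C\c2ccccc2[N+](=O)[O-])CC1`, carries 2-nitrophenyl in place of 4-methylphenyl on a carbon with a double bond to nitrogen. For the measured compounds named here, no step between measured compounds describes this kind of change, so the step from compound 2 to compound 3 is expected to be small, likely none beyond the scatter, in either direction: a 1.0-fold lower number from compound 2 to compound 3 (0.02 log units; within the scatter). Compound 3 is therefore estimated at 6500 nM, within a range from 2500 nM to 17000 nM.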

Compound 3, concentration for 50% growth inhibition: 39900 nM
Compound 3: the middle estimate sits 6.1-fold (0.79 log units) below what was measured; the measured number lies above the stated range.
By their numbers in this assay, from the lowest: compounds 2 and 1 (each within the scatter of the next); then compound 3.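

In this assay, this place on the carbon with a double bond to nitrogen proves sensitive to the aromatic group it carries: 2-nitrophenyl in place of 4-methylphenyl gives a 5.9-fold higher number from compound 2 to compound 3 (0.77 log units; beyond the scatter), weaker inhibition of growth. Compound 1 and compound 2 had stood within the scatter of each other, so this is the first change shown that clearly moves the number. No measurement bears on why the number rises.

From the compounds shown here alone, whether the nitro group or the absent methyl carries the step stays open. So does what a plain phenyl, a methoxyphenyl or an aminophenyl would give here.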